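Compound 4: one ring swapped on the ether oxygen

The compounds below may be only part of what the source reports. "The series", "measured", "known", "first", "only" and "open" are said of these compounds alone.

Compound 1 `CC(C)(C)C#Cc1cc(N(C(=O)[C@H]2CC[C@H](C)CC2)[C@H]2CC[C@H](Oc3ccc4nccn4n3)CC2)c(C(=O)O)s1`: 133 nM
Compound 2 `CC(C)(C)C#Cc1cc(N(C(=O)[C@H]2CC[C@H](C)CC2)[C@H]2CC[C@H](OC3CCOCC3)CC2)c(C(=O)O)s1`: 1990 nM
Compound 3 `CC(C)(C)C#Cc1cc(N(C(=O)[C@H]2CC[C@H](C)CC2)[C@H]2CC[C@H](Oc3ccc(=O)[nH]n3)CC2)c(C(=O)O)s1`: 1480 nM

All three values come from an ADME assay on MT4 cells (Homo sapiens) for cytotoxicity, with a stated time of 5 days; a higher number here means that more compound is tolerated, a lower number that less compound is tolerated. Compound 3 sits in the upper pair, and the data show a 1.3-fold lower number from compound 2 to compound 3 (0.13 log units; within the scatter). The clear gap lies elsewhere, with an 11-fold higher number from compound 1 to compound 3 (1.05 log units; beyond the scatter) and a 15-fold higher number from compound 1 to compound 2 (1.18 log units; beyond the scatter).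

Compound 4 `CC(C)(C)C#Cc1cc(N(C(=O)[C@H]2CC[C@H](C)CC2)[C@H]2CC[C@H](Oc3ccccn3)CC2)c(C(=O)O)s1` keeps the shared core and changes only the group on the oxygen: a group of 6 heavy atoms (5 carbon, 1 nitrogen; one six-membered aromatic ring with 1 hetero atom) in place of a group of 7 heavy atoms (4 carbon, 2 nitrogen, 1 oxygen; one six-membered aromatic ring with 2 hetero atoms), on an oxygen on a saturated carbon. The entering group is pyridin-2-yl.

For the measured compounds named here, no measured step makes this exact swap, but all three steps change the same place, so they offer the nearest guide. Compound 4 carries a single six-membered aromatic ring, as compound 3 does at 1480 nM, and not the two-ring group of compound 1 at 133 nM. Going by the values given here, with only three compounds this is a weak guide, so a moderate move towards compound 1 is expected rather than a large one. The expected step is a 2.5-fold lower number from compound 3 to compound 4 (0.39 log units; beyond the scatter). For compound 4 the estimated value is 600 nM, with an expected range of 170 nM to 2000 nM.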

Compound 4, half-maximal cytotoxic concentration in the MT4 assay: 100 nM
Compound 4: middle estimate off by 6.0-fold (0.78 log units), on the high side, outside the stated range (below it).
By their numbers in the MT4 assay, from the lowest: compounds 4 and 1 (each within the scatter of the next); then compounds 3 and 2 (each within the scatter of the next).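

Within the MT4 assay, a single aromatic ring on this oxygen is not enough to keep the number high: the data show a 15-fold lower number from compound 3 to compound 4 (1.17 log units; beyond the scatter), and also a 20-fold lower number from compound 2 to compound 4 (1.30 log units; beyond the scatter). The pyridin-2-yl group instead falls with the two-ring group of compound 1, with a 1.3-fold lower number from compound 1 to compound 4 (0.12 log units; within the scatter), so ring count alone does not sort these compounds, as compound 3 and compound 4 both carry one ring. In a physicochemical assay for lipophilicity (a higher number here means a more lipophilic compound, a lower number a more polar compound), the swap from compound 3 (2) to compound 4 (3) gives a more lipophilic compound, which may be linked to the lower tolerated concentration, though a single pair cannot prove it: the measured distribution coefficient of compound 3, 2, and of compound 4, 3, a number 1.00 log units higher (beyond the scatter)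

The compounds shown leave open whether that link holds beyond this one pair. They also leave open whether a pyridin-2-yl ring carrying an amine or a carboxylic acid would return to the numbers of compound 2 and compound 3.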